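Pyrazole Replaces Methylpyridine on a Shared Core

The source may report more compounds than this note shows. Statements on the series, on what has been measured and on what is new or still open speak of the compounds shown alone.

In an ADME assay on L6 cells (Rattus norvegicus) for cytotoxicity, read by fluorescence and resazurin assay, with a stated time of 72 h (a lower number here means that less compound is needed, a higher number that more compound is needed for the effect), compound 1 `Cc1ccc(-c2ccc3[nH]c(=O)nc(-c4ccccc4)c3c2)cn1` reaches only the limit of the assay, giving > 50000 nM. Compound 2 `Cc1ccncc1-c1ccc2[nH]c(=O)nc(-c3ccccc3)c2c1` likewise shows only a limit in this assay, > 50000 nM. Within the data shown here, the single measured step, a step that the two limits leave unreadable from compound 1 to compound 2, therefore cannot be sized, with both ends resting at the same limit, as the limit of > 50000 nM in this assay, at which 2 of the 2 values shown sit, records. Compound 3 `Cn1nccc1-c1ccc2[nH]c(=O)nc(-c3ccccc3)c2c1` has not yet been measured in this assay. It differs from compound 1 by 1-methyl-1H-pyrazol-5-yl in place of 6-methylpyridin-3-yl on an aromatic carbon. Among the measured compounds shown here, no measured step speaks directly to this change, and the one step that exists is unreadable, so nothing in the numbers points to a shift in either direction. Since both measured compounds sit at the limit, compound 3 is expected to behave in the same way and to show no step beyond the scatter, a number no higher from compound 1 to compound 3 (the limit leaves the size open). Compound 3 is accordingly estimated at 50000 nM, with a range from 20000 nM to 120000 nM, and it is expected that this assay will most likely report only a limit for it once more.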

Compound 3, half-maximal effective concentration: > 50000 nM
Compound 3 was reported as a limit; the forecaster's own chance of this, stated with the estimate: 80%; the middle value sits exactly at the limit.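

Compound 3, like compound 1 and compound 2, gives only a limit in this assay, so none of the steps among these three compounds can be read: the limit of > 50000 nM in this assay, at which 3 of the 3 values shown sit.

The compounds shown leave open whether 1-methyl-1H-pyrazol-5-yl in place of 6-methylpyridin-3-yl changes the result in this assay at all, and what change on the shared core would give a number rather than a limit.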